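Cytotoxicity in HepG2 cells: benzyl to cyclohexyl on the shared core

The source may report more compounds than this note shows. Statements on the series, on what has been measured and on what is new or still open speak of the compounds shown alone.

Measured compounds, with the read-out from an ADME assay on HepG2 cells (Homo sapiens) for cytotoxicity, read by luminescence, CellTiter-Glo and ATP content, with a stated time of 72 h; on this read-out higher numbers stand for an effect only at larger amounts of compound and lower numbers for an effect already at smaller amounts:
- compound 1, `c1ccc(CCc2ccc3c(NCCCNCc4ccco4)ccnc3c2)cc1`, compound 1 gives 16000 nM
- compound 2, `COc1ccc(F)cc1CNCCCNc1ccnc2cc(Cc3ccccc3)ccc12`, compound 2 gives 7990 nM
- compound 3, `COc1ccc(Oc2ccc3c(NCCCNCc4cccc(OC)c4O)ccnc3c2)cc1`, compound 3 gives 5500 nM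

Compound 1 stands at the highest of the three numbers in this assay. The gap to compound 2 lies within the scatter, so the two cannot be ordered; the gap to compound 3 lies beyond the scatter, and compound 3 shows an effect at smaller amounts than compound 1. For the measured compounds named here, the three compounds differ in more than one place, so no single step between them can be read off.

Compound 4, `c1coc(CNCCCNc2ccnc3cc(CC4CCCCC4)ccc23)c1`, has not been measured in this assay. It differs from compound 1 in one place: cyclohexyl in place of benzyl on a saturated chain carbon bound to an aromatic carbon. The difference is the same cut one bond further out: phenethyl to cyclohexylmethyl. Going by the values given here, no measured pair isolates this change, so the expectation for the step rests on the shared core alone. Compound 4 is expected to stay close to compound 1, the step from compound 1 to compound 4 estimated as a 1.3-fold lower number from compound 1 to compound 4 (0.12 log units; within the scatter), not beyond the scatter in either direction. For compound 4 the estimate in this assay is 12000 nM, with a range from 5000 nM to 30000 nM.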

Compound 4, half-maximal effective concentration: 1700 nM
For compound 4 the middle estimate is 7.1-fold (0.85 log units) above the measured one; measured number outside the range, below it.
By their numbers in this assay, from the lowest: compound 4; then compounds 3, 2 and 1 (each within the scatter of the next, the first and the last beyond it).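

For the compounds shown here, earlier compounds differed in more than one place, so this is the first single change that can be read: in this assay, cyclohexyl in place of benzyl on a saturated chain carbon bound to an aromatic carbon gives a 9.4-fold lower number from compound 1 to compound 4 (0.97 log units; beyond the scatter). This position is therefore not indifferent to the group it carries, as a swap of one six-membered carbon ring for another, with one heavy atom fewer leaving, is enough to produce a step beyond the scatter. Neither group counts any hydrogen-bond donors, hydrogen-bond acceptors or net charge, and no measurement at hand accounts for the step.

Going by these compounds alone, the single pair leaves open whether the step follows from the loss of the aromatic ring, from the loss of one carbon in the linking chain, or from both, and a phenyl or cyclohexylethyl group in the same place would begin to separate these. As far as these compounds go, it also remains open whether the same change gives a similar step when the rest of the molecule differs, and whether a piperidine ring or an open hexyl chain would behave like cyclohexyl here.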